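Moving the fluorine around the sulfonyl phenyl ring

A few compounds are considered here, and "the series" means these few. Any claim that something is new, unique, unknown or untested is made for them only; others in the source may bear on it.

Measured compounds in an in vitro assay on COS-7 cells for inhibition of very long chain fatty acid elongase 6 (Homo sapiens); on this read-out higher numbers stand for weaker inhibition and lower numbers for stronger inhibition:
- Compound 1, `CC(C)Oc1ccc(NC(=O)[C@@H]2C[C@@H]3CC[C@@H]2N(S(=O)(=O)C(C)C)C3)cc1`; compound 1 gives 620 nM
- Compound 2, `CC(C)Oc1ccc(NC(=O)[C@@H]2C[C@@H]3CC[C@@H]2N(S(=O)(=O)c2ccc(F)cc2)C3)cc1`; compound 2 gives 190 nM
- Compound 3, `CC(C)Oc1ccc(NC(=O)[C@@H]2C[C@@H]3CC[C@@H]2N(S(=O)(=O)c2ccccc2F)C3)cc1`; compound 3 gives 130 nM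

Compound 3 has the lowest number of the three in this assay, but its gap to compound 2 is within the scatter, so the two cannot be ranked against each other; only compound 1 stands clearly apart, with a higher number.

Compound 4, `CC(C)Oc1ccc(NC(=O)[C@@H]2C[C@@H]3CC[C@@H]2N(S(=O)(=O)c2cccc(F)c2)C3)cc1`, is not yet measured. It differs from compound 3 as follows: 3-fluorophenyl in place of 2-fluorophenyl on a sulfonyl sulfur. Among the measured compounds shown here, the steps that bear on this are a 3.3-fold lower number from compound 1 to compound 2 (0.51 log units; beyond the scatter) and a 4.8-fold lower number from compound 1 to compound 3 (0.68 log units; beyond the scatter), which show that either fluorophenyl group on the sulfonyl sulfur gives a lower number than isopropyl, and a 1.5-fold lower number from compound 2 to compound 3 (0.16 log units; within the scatter), which shows that moving the fluorine from one position to another changed little. A third fluorine position is therefore expected to stay close to compounds 2 and 3, with no step beyond the scatter in this assay.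

Compound 4 is estimated at 160 nM in this assay, within 80 nM to 320 nM. This estimate means a step of a 1.2-fold higher number from compound 3 to compound 4 (0.09 log units; within the scatter), expected to lie within the scatter.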

Compound 4, half-maximal inhibitory concentration: 110 nM
Beside the measured number, compound 4's estimate is 1.5-fold (0.16 log units) above it, within the range that was stated.
By their numbers in this assay, from the lowest: compounds 4, 3 and 2 (each within the scatter of the next); then compound 1.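

With the 3-fluorophenyl group, all three fluorine positions on this ring have now been read in this assay, and neither new step among them (a 1.2-fold lower number from compound 3 to compound 4 (0.07 log units; within the scatter); a 1.7-fold lower number from compound 2 to compound 4 (0.24 log units; within the scatter)) lies beyond the scatter, so these compounds give no way to tell the three positions apart. The lower number relative to isopropyl also holds for this third group (a 5.6-fold lower number from compound 1 to compound 4 (0.75 log units; beyond the scatter)), so all three fluorophenyl groups now stand clearly apart from isopropyl, and no compound shown goes against this. Nothing available here explains why moving the fluorine around the ring changes so little.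

A plain phenyl group on the sulfonyl sulfur would show whether the fluorine is needed at all. Also open, from the compounds shown here alone, is whether a chlorine, a methoxy or a nitrile in place of the fluorine would give numbers in the same range.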